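Extending the amine chain to an oxanyl amine

This account rests on a few compounds, and the source may have more. Where it says the series, first, only, none or still open, it means among the compounds named here.

The series rests on a shared core, seen in compound 1 `NCCCCN(C[C@@H]1Cc2nccnc2CN1)[C@H]1CCCc2cccnc21` and compound 2 `NC/C=C\CN(C[C@H]1Cc2ncccc2CN1)[C@H]1CCCc2cccnc21`. In an ADME assay on microsomes from liver (Homo sapiens) for metabolic stability, using NADPH, with a stated time of 10 min (on this read-out higher numbers stand for a more stable compound and lower numbers for a less stable compound), compound 1 gives 87%. In this assay compound 2 gives 85%; that number lies within the scatter of the value of compound 1, so the two compounds cannot be told apart on this read-out.

Compound 3 `c1cnc2c(c1)CN[C@@H](CN(CCCCNC1CCOCC1)[C@H]1CCCc3cccnc31)C2` has not yet been measured. It differs from compound 2 in one place: 3-((oxan-4-yl)amino)propyl in place of 3-aminoprop-1-en-1-yl on a saturated chain carbon bound to an amine nitrogen. Going by the values given here, no measured pair in the set shows a change of this kind, so its effect can only be estimated. Starting from the high value of compound 2 in this assay, 85%, the larger group is expected to lower the read-out by a moderate step, a number 13 percentage points lower from compound 2 to compound 3 (beyond the scatter), probably a little beyond the scatter. Compound 3 is therefore estimated at 72%, within a range from 45% to 92%.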

Compound 3, percent of the compound remaining: 97%
Beside the measured number, compound 3's estimate is 25 percentage points below it, outside the stated range (above it).
By their numbers in this assay, from the lowest: compounds 2, 1 and 3 (each within the scatter of the next, the first and the last beyond it).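

Going by these compounds alone, at this place, a saturated chain carbon bound to an amine nitrogen, the earlier compounds offered no step, and compound 3 now supplies the first. In this assay, the larger 3-((oxan-4-yl)amino)propyl, with its six-membered non-aromatic ring, gives a number 12 percentage points higher from compound 2 to compound 3 (beyond the scatter), a modest step, so the larger group brings no loss on this read-out. Nothing measured here explains this rise.

The change removes a double bond and adds both a ring and an oxygen in a single step, so the compounds shown leave open which of these differences accounts for the higher number. They also leave open whether a cyclohexyl or piperidin-4-yl group in place of the oxan-4-yl ring, on the same propyl chain, would give a similar reading.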